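Shortening a Thioether Chain in Mouse Activation

The compounds below may be only part of what the source reports. "The series", "measured", "known", "first", "only" and "open" are said of these compounds alone.

Among the measured compounds shown here, compound 1 `CCCCCSc1nc(N)c2nc(O)n(Cc3ccccc3)c2n1` gives the only number among the two compounds tested in a functional assay on the whole organism for activation, with Mus musculus as the target (on this read-out higher numbers stand for an effect only at larger amounts of compound and lower numbers for an effect already at smaller amounts), namely 1 mg/kg. Compound 2 `Nc1ncnc2c1nc(S)n2Cc1ccccc1` reaches only a limit of the assay in this assay, > 30 mg/kg, and yields no number; this is the limit of > 30 mg/kg in this assay, at which 1 of the 2 values shown sits. Compound 3 `CCCCSc1nc(N)c2nc(O)n(Cc3ccccc3)c2n1` is not yet measured. It differs from compound 1 by hydrogen in place of methyl on a saturated chain carbon, four bonds along the chain from a sulfur. For the measured compounds named here, no step between two measured compounds is available to set the size of such a change. The change is expected to amount to no change at the digits printed from compound 1 to compound 3 (within the scatter), nothing beyond the usual scatter. Compound 3 is therefore estimated to give 1 mg/kg in this assay, between 0.3 mg/kg and 3 mg/kg.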

Compound 3, minimum effective dose: 0.3 mg/kg
Compound 3: the middle estimate sits 3.3-fold (0.52 log units) above what was measured, within the range that was stated.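

In this assay, hydrogen in place of methyl on a saturated chain carbon, four bonds along the chain from a sulfur, gives a 3.3-fold lower number from compound 1 to compound 3 (0.52 log units; beyond the scatter) as the first step read at this place. The outer end of the thioether chain therefore matters: the shorter butyl chain of compound 3 acts at smaller amounts than the pentyl chain of compound 1. Nothing shown gives a cause for this step.

On these data alone, whether a propyl or ethyl chain would extend this direction remains open, as does the effect of a hexyl chain or a terminal amine. A single step establishes no trend along the chain.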